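Aryl Ether to Aryl Sulfone on the Propyl Chain

The compounds below may be only part of what the source reports. "The series", "measured", "known", "first", "only" and "open" are said of these compounds alone.

Two compounds of this diphenylmethyl-piperidine series have numbers in a functional assay (aorta) with Oryctolagus cuniculus as the target; a lower number here means tighter binding, a higher number weaker binding. Compound 1 `COc1cc(C(C)=O)ccc1OCCCN1CCC(C(c2ccccc2)c2ccc(F)cc2)CC1` gives 6.31 nM. Compound 2 `Fc1ccc(OCCCN2CCC(C(c3ccc(F)cc3)c3ccc(F)cc3)CC2)cc1` gives 1.26 nM, the lowest number of the two; the gap to compound 1 lies beyond the usual scatter.

Compound 3 `O=S(=O)(CCCN1CCC(C(c2ccc(F)cc2)c2ccc(F)cc2)CC1)c1ccccc1` has not been measured. Relative to compound 2 the change is phenylsulfonyl in place of 4-fluorophenoxy on a saturated chain carbon, three bonds along the chain from an amine nitrogen in a ring. The 4-fluorophenoxy group is lost and a phenylsulfonyl group takes its place on the same saturated chain carbon, three bonds along the chain from the amine nitrogen in the ring; the shared core is otherwise untouched.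

Among the compounds with values here, no measured pair within the set carries this change, so the size of the step rests on judgment. A moderate rise in the number is expected from compound 2 to compound 3, a 3.2-fold higher number from compound 2 to compound 3 (0.50 log units; beyond the scatter), probably just beyond the scatter. Compound 3 is therefore estimated at 4 nM in this assay, within a range from 1 nM to 20 nM.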

Compound 3, dissociation constant: 20 nM
Compound 3: middle estimate off by 5.0-fold (0.70 log units), on the low side; low and high end bracket the measured number.
By their numbers in this assay, from the lowest: compound 2; then compound 1; then compound 3.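

The saturated chain carbon three bonds along the chain from the amine nitrogen in the ring proves sensitive in this assay: phenylsulfonyl in place of 4-fluorophenoxy gives a 16-fold higher number from compound 2 to compound 3 (1.20 log units; beyond the scatter) and marks this exchange as a large one. The six-membered aromatic ring of carbon only and the absence of net charge are common to both groups, so the presence of that ring alone does not set the number at this position. No measurement here accounts for the rise.

The step replaces the ether oxygen with the sulfonyl and removes the ring fluorine together, and these two changes cannot be told apart. Open, going by these compounds, is how 4-fluorophenylsulfonyl or plain phenoxy on the same carbon would read in this assay.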